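The compounds below may be only part of what the source reports. "The series", "measured", "known", "first", "only" and "open" are said of these compounds alone.

Measured compounds:
Compound 1, `O=C(CCCCCc1ccccc1)c1nc2cccc(Br)c2o1`, gives > 10000 nM in an assay on HEK-293T cells for inhibition of diacylglycerol lipase-alpha (Homo sapiens), read by colorimetric assay (a lower number here means a stronger inhibitor, a higher number a weaker inhibitor), which is a limit of the assay and not a number.
Compound 2, `Cn1nnc(C(=O)CCCCCCc2ccccc2)n1`, gives > 10000 nM in this assay, again only a limit.
Compound 3, `CC(=O)c1coc(C(=O)CCCCCCc2ccccc2)n1`, gives 123 nM in this assay.

Compound 3 is therefore the only one of the three with a numerical result; the other two values sit at the limit of > 10000 nM in this assay, at which 2 of the 3 values shown sit, so no comparison of size can be made between compound 3 and either of them beyond saying that compound 3 has a number and they do not.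

Compound 4, `CN(C)C(=O)c1coc(C(=O)CCCCCCc2ccccc2)n1`, has not yet been measured. It differs from compound 3 by dimethylamino in place of methyl on a carbonyl carbon. For the measured compounds named here, no step between two measured compounds is available to gauge what such a change does in this assay. The expected step is a 2.0-fold higher number from compound 3 to compound 4 (0.31 log units; beyond the scatter), modest and leaning toward weaker inhibition, though a result within the usual scatter would not be surprising. Compound 4 is expected to give about 250 nM in this assay, with a likely range from 50 nM to 1500 nM.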

Compound 4, half-maximal inhibitory concentration: 3390 nM
For compound 4 the middle estimate is 14-fold (1.13 log units) below the measured one, and the stated range ends below it.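

In this assay, for the compounds shown here, the change from acetyl to dimethylcarbamoyl gives a 28-fold higher number from compound 3 to compound 4 (1.44 log units; beyond the scatter) and so shows that the group on this carbonyl carbon matters a great deal for the result, which the earlier compounds, with no step between them, could not show. Compound 4 still has a numerical result rather than a limit, so this change weakens inhibition without removing a measurable value. Nothing measured here accounts for the size of this step.

The compounds shown leave open how a methylamino group, a plain amino group or a methoxy group would read on this same carbonyl carbon. They therefore cannot separate what the nitrogen contributes to the step from what the two methyl groups on it contribute.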